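A few compounds are considered here, and "the series" means these few. Any claim that something is new, unique, unknown or untested is made for them only; others in the source may bear on it.

Measured in a functional assay on KB cells (Homo sapiens) for cytotoxicity, read by sulforhodamine B assay, with a stated time of 3 days; on this read-out higher numbers stand for an effect only at larger amounts of compound and lower numbers for an effect already at smaller amounts:
- compound 1 `COC(=O)c1c(C)coc1-c1ccc2c(c1OC)CCCC2(C)C`: 53.4 uM
- compound 2 `Cc1coc(-c2ccc3c(c2O)CCCC3(C)C)c1C(=O)O`: 4.7 uM
- compound 3 `CCc1cccc2c(O)c(-c3occ(C)c3C(=O)O)ccc12`: 30.7 uM

Compound 1, at 53.4 uM, stands at the high-number end of this small set. It lies within the scatter of compound 3 and beyond the scatter of compound 2, which has the lower number.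

Compound 4 `COc1c(-c2occ(C)c2COC(C)=O)ccc2c1CCCC2(C)C` keeps the core of compound 1 and differs by one change: acetoxymethyl in place of methoxycarbonyl on an aromatic carbon. Going by the values given here, no measured pair covers this change, so the expectation rests on compound 1 alone, and no step beyond the scatter is expected in this assay. The estimated move is a 1.2-fold lower number from compound 1 to compound 4 (0.07 log units; within the scatter). For compound 4 the estimate is 45 uM, with an expected range of 17 uM to 100 uM.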

Compound 4, concentration for half-maximal effect: 25.4 uM
Beside the measured number, compound 4's estimate is 1.8-fold (0.25 log units) above it, within the range that was stated.
By their numbers in this assay, from the lowest: compound 2; then compounds 4, 3 and 1 (each within the scatter of the next, the first and the last beyond it).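

Acetoxymethyl in place of methoxycarbonyl on this aromatic carbon gives the first single-change step in the series: in this assay there is a 2.1-fold lower number from compound 1 to compound 4 (0.32 log units; beyond the scatter). The position therefore accepts this exchange with a modest shift towards effect at smaller amounts of compound, though the shift lies only just beyond the scatter. Nothing available bears on the reason for this step.

Going by these compounds, how hydroxymethyl or a primary amide at this position would read on the core of compound 1 remains open. So does whether the same exchange would give a similar step on the core of compound 2.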